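Second Trifluoromethyl Group and Cytotoxicity in Kidney Cells

A few compounds are considered here, and "the series" means these few. Any claim that something is new, unique, unknown or untested is made for them only; others in the source may bear on it.

Measured so far:
Compound 1 `COc1cc(NC(=O)c2cccc(C(F)(F)F)c2)ccc1NS(=O)(=O)C(F)(F)F` gives in an ADME assay on HEK293 cells (Homo sapiens) for cytotoxicity, read by MTT assay, with a stated time of 48 h (a higher number here means a weaker inhibitor, a lower number a stronger inhibitor), only a limit, > 250000 nM.
Compound 2 `COc1cc(NC(=O)c2cc(C(F)(F)F)cc(C(F)(F)F)c2)ccc1NS(=O)(=O)C(F)(F)F` gives in this assay only a limit, > 250000 nM.
Compound 3 `CCS(=O)(=O)Nc1ccc(NC(=O)c2cccc(C(F)(F)F)c2)cc1F` gives in this assay a value of 94800 nM.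

Compound 4 `CCS(=O)(=O)Nc1ccc(NC(=O)c2cc(C(F)(F)F)cc(C(F)(F)F)c2)cc1F` has not yet been measured in this assay. It arises from compound 3 by the change (trifluoromethyl in place of hydrogen on an aromatic carbon). The same change, (trifluoromethyl in place of hydrogen on an aromatic carbon), links compound 1 to compound 2, and there the step that the two limits leave unreadable from compound 1 to compound 2. How the core of compound 3 differs from the core of compound 1 is not broken down here.

For the measured compounds named here, since the two values at the limit of > 250000 nM in this assay, at which 2 of the 3 values shown sit, leave the earlier step unreadable, the only guide is that both compounds with and without the second trifluoromethyl group sit at the limit. The expected step is therefore a 1.6-fold higher number from compound 3 to compound 4 (0.20 log units; within the scatter), a small move toward weaker inhibition, and the estimate is uncertain. For compound 4 the expected value is 150000 nM, estimated to lie between 60000 nM and 250000 nM, with a fair chance that only a limit is reported.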

Compound 4, half-maximal inhibitory concentration: > 250000 nM
Compound 4: only a limit was reported; the forecaster's own chance of this, stated with the estimate: 50%; middle value at least 1.6-fold (0.22 log units) away from the limit.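

In this assay, the second trifluoromethyl group brings an at least 2.6-fold higher number from compound 3 to compound 4 (0.42 log units; beyond the scatter), so on this core the change moves the number toward weaker inhibition, by more than the usual scatter. Compound 4 gives only a limit, > 250000 nM, so the full size of this step is not known. The step from compound 1 to compound 2 cannot be read, so these data neither confirm nor refute that the change carries over from one core to the other, and most of the values shown sit at a single point: the limit of > 250000 nM in this assay, at which 3 of the 4 values shown sit.

The compounds shown leave open whether the step would look the same on a core whose values lie well clear of the limit, where both compounds of a pair could be read as true numbers. They also leave open how a different group at the same place on the aromatic ring, such as a nitrile, an amine or a carboxylic acid, would move the number in this assay.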